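The source may report more compounds than this note shows. Statements on the series, on what has been measured and on what is new or still open speak of the compounds shown alone.

Measured compounds in a functional assay on A2780 cells (Homo sapiens) for inhibition; a higher number here means a weaker inhibitor, a lower number a stronger inhibitor:
- compound 1 `CCNC(=O)c1noc(-c2cc(C(C)C)c(O)cc2O)c1-c1cc(CO)no1`: 5 nM
- compound 2 `CCCNCc1cc(-c2c(C(=O)NCC)noc2-c2cc(C(C)C)c(O)cc2O)on1`: "not determined" (no result reported)
- compound 3 `CCNC(=O)c1noc(-c2cc(C(C)C)c(O)cc2O)c1-c1cc(CNC(C)=O)no1`: "not determined" (no result reported)

Compound 2 has no single number in this assay, and compound 3 stands in the same position, so neither can be placed against compound 1. The only anchor for the series is compound 1, which in this assay gives 5 nM; compound 1 differs from compound 2 and compound 3 in the substituent carried on the five-membered aromatic ring with 1 nitrogen and 1 oxygen, while the shared core is unchanged across all three.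

Compound 4 `CCNC(=O)c1noc(-c2cc(C(C)C)c(O)cc2O)c1-c1cnn(CC)c1` is the next entry. It differs from compound 2 as follows: 1-ethyl-1H-pyrazol-4-yl in place of 3-((propylamino)methyl)-1,2-oxazol-5-yl on an aromatic carbon. For the measured compounds named here, no step between measured compounds touches this position, so no measured size can be assigned to the change; with compound 2 itself unmeasured, the expectation for compound 4 can rest only on compound 1 and the shared core. The reading for compound 4 in this assay is expected to stay in the same region as compound 1, with a modest weakening allowed for, as a step of roughly the scatter or somewhat beyond it toward weaker inhibition.

Compound 4 is estimated at 15 nM in this assay, with a range from 3 nM to 80 nM.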

Compound 4, half-maximal inhibitory concentration: 30 nM
Compound 4: middle estimate off by 2.0-fold (0.30 log units), on the low side, and the stated range covers the measured number.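

In this assay, replacing 3-(hydroxymethyl)-1,2-oxazol-5-yl with 1-ethyl-1H-pyrazol-4-yl on the aromatic carbon gives a 6.0-fold higher number from compound 1 to compound 4 (0.78 log units; beyond the scatter), the first measured size for any change at this position, and it lies beyond the scatter. The position therefore responds to the identity of the group, yet a quite different group is accepted: compound 4, with no hydrogen-bond donor in this substituent, still gives 30 nM on the shared core. Nothing available accounts for the size of this step.

The step changes the ring and its side group together, so their shares cannot be separated; 3-ethyl-1,2-oxazol-5-yl or 1-(2-hydroxyethyl)-1H-pyrazol-4-yl would keep one fixed while changing the other. Also open, as far as these compounds go, is how a carboxylic acid or a longer chain on the same ring would read, and compound 2 and compound 3 offer no number to show how an amine or an amide on the methyl arm compares with the hydroxyl of compound 1.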